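Second methoxy entering the aromatic ring of compound 1

The source may report more compounds than this note shows. Statements on the series, on what has been measured and on what is new or still open speak of the compounds shown alone.

For the measured compounds named here, compound 1 `COc1ccc(/C=C/C2CC=CC(=O)O2)cc1` gives 61.5 uM in a functional assay on OVCAR-3 cells (Homo sapiens) for inhibition, read by sulforhodamine B assay, with a stated time of 48 h (on this read-out lower numbers stand for stronger inhibition of growth and higher numbers for weaker inhibition of growth), the highest of the two numbers measured so far; compound 2 `COc1ccc(/C=C/C2CC=CC(=O)O2)c(OC)c1` gives 5.6 uM. The step of an 11-fold lower number from compound 1 to compound 2 (1.04 log units; beyond the scatter) arose from a methoxy in place of hydrogen on an aromatic carbon. Compound 3 `COc1ccc(/C=C/C2CC=CC(=O)O2)cc1OC` differs from compound 1 thus: methoxy in place of hydrogen on an aromatic carbon. Going by the values given here, only the step from compound 1 to compound 2 bears on this change, and it was large, so a lower number is expected for compound 3, though with less confidence in its size. The expected step is a 3.1-fold lower number from compound 1 to compound 3 (0.49 log units; beyond the scatter). Compound 3 is estimated at 20 uM, range 6 uM to 60 uM.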

Compound 3, concentration for growth inhibition (reported as GI): 16.8 uM
Beside the measured number, compound 3's estimate is 1.2-fold (0.08 log units) above it, and the stated range covers the measured number.
By their numbers in this assay, from the lowest: compound 2; then compound 3; then compound 1.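

At this position, ortho to a methoxy group and meta to a group of 9 heavy atoms, methoxy in place of hydrogen gives a 3.7-fold lower number from compound 1 to compound 3 (0.56 log units; beyond the scatter), a modest step. The change therefore lowers the number at a second ring position, although the earlier step, an 11-fold lower number from compound 1 to compound 2 (1.04 log units; beyond the scatter), was large. No measurement on hand offers an explanation for either step. Open, going by these compounds, is whether a hydroxyl, an amine or a longer alkoxy chain at this position would move the number the same way. Also open, on these data alone, is what a third methoxy on the ring would do.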